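Fluoro in place of amino: notes on compounds 2 and 3

The compounds below may be only part of what the source reports. "The series", "measured", "known", "first", "only" and "open" are said of these compounds alone.

Compound 1 `CC(/C=N/N(C)c1ccc([N+](=O)[O-])cc1)=N\NC(=O)c1ccc(N)cc1` in a functional assay on cells (Splenocyte, Mus musculus, strain BALB/c) for inhibition, read by scintillation counting and thymidine incorporation, with a stated time of 72 h (on this read-out lower numbers stand for stronger inhibition and higher numbers for weaker inhibition), gives > 12000 nM, a limit of the assay rather than a number.
Compound 2 `CC(/C=N/Nc1ccc([N+](=O)[O-])cc1)=N\NC(=O)c1ccccc1N` in this assay gives 4900 nM.

Among the compounds with values here, compound 2 thus holds the only number in this set; the other value is a limit. Compound 3 `CC(/C=N/Nc1ccc([N+](=O)[O-])cc1)=N\NC(=O)c1ccccc1F` differs from compound 2 by fluoro in place of amino on an aromatic carbon. Within the data shown here, no measured pair here shares this change, so nothing in the data sizes it. The step of a 1.2-fold higher number from compound 2 to compound 3 (0.09 log units; within the scatter) is expected to be small, in no direction beyond the usual scatter. Compound 3 is estimated at 6000 nM in this assay, with a likely range from 2000 nM to 18000 nM.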

Compound 3, half-maximal inhibitory concentration: > 12000 nM
Compound 3 ended at the assay's limit (the forecaster's own chance of this, stated with the estimate: 30%); middle value at least 2.0-fold (0.30 log units) from the limit.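

Fluoro in place of amino on an aromatic carbon, ortho to a large group, is not a silent change: in this assay it gives an at least 2.4-fold higher number from compound 2 to compound 3 (0.38 log units; beyond the scatter). Within the data shown here, this is the first measured size for any change at this position, and it favours the 2-aminophenyl compound. The value of compound 3 is a limit of the assay and not a number, so the step has no upper end: the limit of > 12000 nM in this assay, at which 2 of the 3 values shown sit.

Going by these compounds, how far compound 3 truly lies from compound 2 stays open. So does how a hydroxy, methoxy or chloro group would read at this position.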